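A ring swap at the short end of the range

The compounds below may be only part of what the source reports. "The series", "measured", "known", "first", "only" and "open" are said of these compounds alone.

Of the compounds shown here, three have been measured in an ADME assay on microsomes from liver (Mus musculus) for metabolic stability; a lower number here means that the compound disappears faster, a higher number that the compound lasts longer. Compound 1 (`CCn1ncc2c(F)cc(-c3ccc(C(CC)(CC)c4nnc[nH]4)c(=O)[nH]3)cc21`) reports > 3 h, which is a limit of the assay. Compound 3 (`CCC(CC)(c1nnc[nH]1)c1ccc(-c2ccc3cccc(F)c3c2)[nH]c1=O`) gives 0.447 h. Compound 2 (`CC(C)C(Cc1nnc[nH]1)c1ccc(-c2ccc3cccc(F)c3c2)[nH]c1=O`) reports < 0.0667 h, again a limit and not a number, and it sits at the short end of the three. Compound 4 (`CC(C)C(Cc1noc(=O)[nH]1)c1ccc(-c2ccc3cccc(F)c3c2)[nH]c1=O`) differs from compound 2 in one place: a group of 6 heavy atoms (2 carbon, 2 nitrogen, 2 oxygen; one five-membered aromatic ring with 3 hetero atoms) in place of a group of 5 heavy atoms (2 carbon, 3 nitrogen; one five-membered aromatic ring with 3 hetero atoms), on a saturated chain carbon, two bonds along the chain from an aromatic carbon. Within the data shown here, no measured pair shows this swap alone, so any forecast is uncertain. Only a small lengthening, close to the scatter, is expected in this assay, as an estimated at least 1.1-fold higher number from compound 2 to compound 4 (0.07 log units; that floor lies within the scatter). Compound 4 is estimated at 0.08 h, with an expected range of 0.05 h to 0.25 h.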

Compound 4, half-life: 2.78 h
Compound 4: the middle estimate sits 35-fold (1.54 log units) below what was measured; measured number above the stated range.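

Putting the new ring in place of the 4H-1,2,4-triazol-3-yl group, on the same saturated chain carbon, gives an at least 41-fold higher number from compound 2 to compound 4 (1.61 log units; beyond the scatter) in this assay, so this single place can strongly change how long the compound lasts. From the compounds shown here alone, compound 2 reports a limit and not a number, so the true size of the step stays open: the limit of < 0.0667 h in this assay, at which 1 of the 4 values shown sits. Still open, going by these compounds, is whether the same swap lengthens the half-life of compound 3, and whether a carboxylic acid or an amine at this place would do the same.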